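Swapping Methoxy for Pyridin-3-yl on the Amide Nitrogen

The source may report more compounds than this note shows. Statements on the series, on what has been measured and on what is new or still open speak of the compounds shown alone.

Compound 1 `Cc1ccc(OCC(=O)N(Cc2cccs2)c2ncccn2)cc1` gives 3700 nM in an assay on HEK293 cells for agonist activity at transient receptor potential cation channel subfamily M member 8 (Homo sapiens), read by fluorescence and calcium flux, with a stated time of 15 min; a higher number here means that more compound is needed for the effect, a lower number that less compound is needed.
Compound 2 `Cc1ccc(OCC(=O)N(Cc2cccs2)c2ccnn2C)cc1` gives 422 nM in this assay.
Compound 3 `CON(Cc1cccs1)C(=O)COc1ccc(C)cc1` gives 10 nM in this assay.

Among the three measured compounds, compound 3 stands lowest in this assay; the nearest is compound 2, and compound 1 lies furthest away. The two steps that lead to compound 3 both exchange an aromatic heterocycle on the amide-type nitrogen for methoxy: a 370-fold lower number from compound 1 to compound 3 (2.57 log units; beyond the scatter) and a 42-fold lower number from compound 2 to compound 3 (1.63 log units; beyond the scatter). Both are large and run in the same direction.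

Compound 4 `Cc1ccc(OCC(=O)N(Cc2cccs2)c2cccnc2)cc1` reverses this kind of exchange: pyridin-3-yl in place of methoxy on an amide-type nitrogen. Since both measured steps that put an aromatic ring in place of methoxy on this nitrogen carried large rises in the number, the step to compound 4 is expected to be a large rise as well. The two measured rings differ widely from one another, so the size of the rise is uncertain, and the six-membered ring with one hetero atom in compound 4 matches neither exactly. Compound 4 is expected to give 700 nM, within 150 nM to 4000 nM, which means an expected step of a 70-fold higher number from compound 3 to compound 4 (1.85 log units; beyond the scatter).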

Compound 4, half-maximal effective concentration: 198 nM
Estimate against measurement, compound 4: 3.5-fold (0.55 log units) above; low and high end bracket the measured number.
By their numbers in this assay, from the lowest: compound 3; then compound 4; then compound 2; then compound 1.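

The new compound shows that the penalty for replacing methoxy on this amide-type nitrogen extends to a third aromatic ring: in this assay the change remains large (a 20-fold higher number from compound 3 to compound 4 (1.30 log units; beyond the scatter)), and no compound shown goes against the finding that each ring gives a higher number than methoxy. It also shows that the identity of the ring matters, since pyridin-3-yl gives a much lower number than pyrimidin-2-yl (a 19-fold lower number from compound 1 to compound 4 (1.27 log units; beyond the scatter)) but only a modest gain over 1-methyl-1H-pyrazol-5-yl, though one still beyond the scatter (a 2.1-fold lower number from compound 2 to compound 4 (0.33 log units; beyond the scatter)). No evidence is available to explain why the ring groups rank in this order or why methoxy stands apart from them.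

On these data alone, it remains open whether the low number is particular to methoxy or would carry over to ethoxy, a longer alkoxy chain or a plain methyl on this nitrogen, and where an unsubstituted phenyl ring would fall among the aromatic rings. All four compounds share the rest of the core, so it is also unknown whether this order would hold if the groups elsewhere on the core were changed.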